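The compounds below may be only part of what the source reports. "The series", "measured", "known", "first", "only" and "open" are said of these compounds alone.

Going by the values given here, in a functional assay on HepG2 cells (Homo sapiens) for inhibition, read by MTT assay, with a stated time of 48 h (on this read-out higher numbers stand for weaker inhibition and lower numbers for stronger inhibition), three compounds built on a shared core have numbers so far. Compound 1 (`CS(=O)(=O)Nc1ccc(-n2cc(-c3ccccc3)nn2)cc1Oc1ccccc1`) gives 13600 nM, compound 2 (`Cc1cc(OCc2cn(-c3ccc(NS(C)(=O)=O)c(Oc4ccccc4)c3)nn2)ccc1Cl`) gives 9800 nM, and compound 3 (`CS(=O)(=O)Nc1ccc(-n2cc(COc3ccc4ccccc4c3)nn2)cc1Oc1ccccc1`) gives 19500 nM. Compound 1 stands within the usual scatter of both others, and the three numbers cannot be put in a firm order.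

Compound 4 (`Cc1ccc(-c2cn(-c3ccc(NS(C)(=O)=O)c(Oc4ccccc4)c3)nn2)cc1`) has not yet been measured. It differs from compound 1 by one small change, methyl in place of hydrogen on an aromatic carbon, which turns phenyl into 4-methylphenyl: methyl in place of hydrogen on an aromatic carbon.

Among the compounds with values here, no measured step makes this exact change, so the evidence is indirect. Two steps alter the same part of the structure: a 1.4-fold lower number from compound 1 to compound 2 (0.14 log units; within the scatter), with (4-chloro-3-methylphenoxy)methyl in place of phenyl, and a 2.0-fold higher number from compound 2 to compound 3 (0.30 log units; within the scatter), with naphthalen-2-yl in place of 4-chloro-3-methylphenyl. Each exchanged far more than a single methyl, yet neither left the scatter. A step beyond the scatter is therefore not expected in this assay, and no direction can be argued with confidence. The expected change is small, at a 1.0-fold lower number from compound 1 to compound 4 (0.02 log units; within the scatter). For compound 4 the estimated value is 13000 nM, with an expected range from 7000 nM to 24000 nM.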

Compound 4, half-maximal inhibitory concentration: 18300 nM
Compound 4: the middle estimate sits 1.4-fold (0.15 log units) below what was measured, within the range that was stated.
By their numbers in this assay, from the lowest: compounds 2, 1, 4 and 3 (each within the scatter of the next).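

In this assay, going by these compounds alone, the methyl group gives the first direct reading of a single-atom change at this position, on an aromatic carbon of a six-membered aromatic ring of carbon only, para to a large group: the step is a 1.3-fold higher number from compound 1 to compound 4 (0.13 log units; within the scatter) and so does not separate the two compounds. Exchanging the whole substituent at the same place gives a 1.9-fold higher number from compound 2 to compound 4 (0.27 log units; within the scatter) and also stays inside the scatter, so 4-methylphenyl and (4-chloro-3-methylphenoxy)methyl cannot be told apart here, and the new compound adds no firm order to the series. Nothing measured for these compounds offers an explanation of these numbers.

Going by these compounds, it remains open whether any group at this position can produce a step beyond the scatter, for instance an amine, a carboxylic acid or a longer chain in place of the methyl. The four compounds also all keep the rest of the shared core unchanged, so they say nothing about how a change elsewhere in the structure would read in this assay.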